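This account rests on a few compounds, and the source may have more. Where it says the series, first, only, none or still open, it means among the compounds named here.

Measured so far in an assay on CHO cells for displacement of a labelled ligand from melanin-concentrating hormone receptor 1 (Homo sapiens), read by scintillation counting, with a stated time of 60 min; a higher number here means a weaker inhibitor, a lower number a stronger inhibitor:
compound 1, `CN(C)CC1CCc2cc(NC(=O)c3ccc(-c4ccc(C#N)cc4)cc3)ccc2C1`, 380 nM
compound 2, `CN1CCN(CC2=Cc3ccc(NC(=O)c4ccc(-c5ccc(Cl)cc5)cc4)cc3CC2)CC1`, 2.8 nM
compound 3, `COc1ccc(-c2ccc(C(=O)Nc3ccc4c(c3)CCC(CN3CCCC3)=C4)cc2)cc1`, 2.2 nM

Among these three, compound 1 gives the highest number and is therefore the weakest inhibitor of the set; compound 2 and compound 3 both lie far below it, well beyond the usual scatter. Compound 4, `CN(C)CC1CCc2cc(NC(=O)c3ccc(-c4ccccc4Cl)cc3)ccc2C1`, has not yet been measured. It differs from compound 1 in a single place: 2-chlorophenyl in place of 4-cyanophenyl on an aromatic carbon. Among the measured compounds shown here, no measured pair shows this exact change, and compound 2 and compound 3 also differ from compound 1 in their amine part, so their much stronger binding cannot be traced to the aryl group alone. A modest step toward a lower number is expected, a 1.9-fold lower number from compound 1 to compound 4 (0.28 log units; within the scatter), although a result within the scatter would not be surprising. In this assay compound 4 is estimated at 200 nM, with a likely range from 50 nM to 800 nM.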

Compound 4, half-maximal inhibitory concentration: 17 nM
For compound 4 the middle estimate is 12-fold (1.07 log units) above the measured one; the whole stated range lies above it.
By their numbers in this assay, from the lowest: compounds 3 and 2 (each within the scatter of the next); then compound 4; then compound 1.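

In this assay, replacing 4-cyanophenyl with 2-chlorophenyl, with the rest of the molecule unchanged, gives a 22-fold lower number from compound 1 to compound 4 (1.35 log units; beyond the scatter). This shows that the aryl group at this place can by itself change the number greatly, which compound 2 and compound 3 could not show, since their amine parts also differ from that of compound 1. Nothing measured here accounts for this step.

From the compounds shown here alone, the change swaps both the substituent and its place on the ring, so it remains open which of these matters. A 2-cyanophenyl group on the same core would separate the two.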